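The compounds below may be only part of what the source reports. "The series", "measured", "known", "first", "only" and "open" are said of these compounds alone.

Readings in a functional assay on HeLa cells (Homo sapiens) for antiproliferative activity, with a stated time of 24 h (a lower number here means a stronger inhibitor, a higher number a weaker inhibitor), so far:

Compound 1 `NC(=O)c1c(NC(=O)c2ccccc2Cl)sc2c1CCNC2` gives 45000 nM.
Compound 2 `NC(=O)c1c(NC(=O)c2ccccc2Cl)sc2c1CCN(Cc1ccc(Cl)cc1)C2` gives only > 50000 nM, which is a limit of this assay and not a number.
Compound 3 `NC(=O)c1c(NC(=O)c2ccccc2Cl)sc2c1CCN(Cc1ccc(Cl)cc1Cl)C2` gives 21100 nM.

Compound 3 holds the lowest of the two numbers available; its nearest neighbour is compound 1, with a 2.1-fold lower number from compound 1 to compound 3 (0.33 log units; beyond the scatter). The two remaining steps concern the same amine nitrogen: an at least 1.1-fold higher number from compound 1 to compound 2 (0.04 log units; that floor lies within the scatter), and an at least 2.3-fold lower number from compound 2 to compound 3 (0.37 log units; beyond the scatter), the latter resting on (the limit of > 50000 nM in this assay, at which 1 of the 3 values shown sits).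

Compound 4 `NC(=O)c1c(NC(=O)c2cccc([N+](=O)[O-])c2)sc2c1CCN(Cc1ccc(Cl)cc1Cl)C2` differs from compound 3 elsewhere: 3-nitrophenyl in place of 2-chlorophenyl on a carbonyl carbon. Every measured step in this series changes the substituent on the amine nitrogen in the ring, and none alters the acyl group on the amide nitrogen. Within the data shown here, no measured step therefore bears on the change from compound 3 to compound 4, and the only guidance is that all three measured values sit within a narrow band near the upper reach of this assay.

Without a directly comparable step, the expectation for compound 4 is a step of about none beyond the scatter, a 1.2-fold higher number from compound 3 to compound 4 (0.07 log units; within the scatter). Compound 4 is therefore estimated at 25000 nM, within a range of 8000 nM to 80000 nM, with a real chance that this assay again reports only a limit.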

Compound 4, half-maximal inhibitory concentration: 33000 nM
The estimate for compound 4 lay 1.3-fold (0.12 log units) below the measured number; the range from low to high includes it.
By their numbers in this assay, from the lowest: compounds 3, 4 and 1 (each within the scatter of the next, the first and the last beyond it). At a limit, above all of these: compound 2.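

In this assay, among these compounds, the group on the carbonyl carbon of the amide changes for the first time, and 3-nitrophenyl in place of 2-chlorophenyl gives a 1.6-fold higher number from compound 3 to compound 4 (0.19 log units; within the scatter). At this position, with the 2,4-dichlorobenzyl group held on the amine nitrogen, the two aryl groups cannot be told apart in this assay, even though the entering group carries hydrogen-bond acceptors and the leaving group has none. No measurement at hand bears on the reason for this outcome.

On these data alone, the exchange is read only with the 2,4-dichlorobenzyl group in place, so it stays open whether it would read the same with the 4-chlorobenzyl group of compound 2, whose value is a limit, or with the hydrogen on the amine nitrogen of compound 1. Also open, as far as these compounds go, is whether an amine or a carboxylic acid on the phenyl ring, or an acetyl group in place of the whole (3-nitrophenyl)carbonyl group, would move the number beyond the scatter.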